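A few compounds are considered here, and "the series" means these few. Any claim that something is new, unique, unknown or untested is made for them only; others in the source may bear on it.

In a physicochemical assay for solubility, read by HPLC, with a stated time of 24 h, at pH 7 (a lower number here means a less soluble compound, a higher number a more soluble compound), compound 2 (`OC[C@@H](O[C@H]1CCCN(Cc2ncc[nH]2)[C@H]1c1ccccc1)c1cc(Cl)cc(Cl)c1`) reads 60000 nM and stands within the scatter of compound 1 (`O=C(O)c1cncc(CN2CCC[C@H](O[C@H](CO)c3cc(Cl)cc(Cl)c3)[C@@H]2c2ccccc2)c1`) at 74000 nM while compound 3 (`COC(=O)Nn1c(C[C@H]2CCC[C@H](OCc3cc(C(F)(F)F)cc(C(F)(F)F)c3)[C@@H]2c2ccccc2)n[nH]c1=O`) at 154000 nM stands higher. Compound 4 (`O=C(O)c1ccc(CN2CCC[C@H](O[C@H](CO)c3cc(Cl)cc(Cl)c3)[C@@H]2c2ccccc2)cc1`) departs from compound 2 by one exchange: 4-carboxyphenyl in place of 1H-imidazol-2-yl on a saturated chain carbon bound to an amine nitrogen in a ring with 4-carboxyphenyl in place of 1H-imidazol-2-yl. Among the compounds with values here, the one measured step at that place is a 1.2-fold lower number from compound 1 to compound 2 (0.09 log units; within the scatter) and it brings in the same 1H-imidazol-2-yl, replacing the 5-carboxypyridin-3-yl of compound 1, the nearest measured match to 4-carboxyphenyl. In this assay no shift beyond the scatter is therefore expected, and the estimated step is a 1.2-fold higher number from compound 2 to compound 4 (0.07 log units; within the scatter) at most a slight rise. Compound 4 is estimated at 70000 nM with an expected range of 30000 nM to 150000 nM in this measurement.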

Compound 4, solubility: 85000 nM
For compound 4 the middle estimate is 1.2-fold (0.08 log units) below the measured one; low and high end bracket the measured number.
By their numbers in this assay, from the lowest: compounds 2, 1, 4 and 3 (each within the scatter of the next, the first and the last beyond it).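

In this assay, a third group at this place, on a saturated chain carbon bound to an amine nitrogen in a ring, again leaves the number within the scatter (a 1.4-fold higher number from compound 2 to compound 4 (0.15 log units; within the scatter)) and (a 1.1-fold higher number from compound 1 to compound 4 (0.06 log units; within the scatter)). The 4-carboxyphenyl, 5-carboxypyridin-3-yl and 1H-imidazol-2-yl groups thus cannot be told apart here, though the six-membered ring of carbon only is new. The compounds shown leave open whether an amine, or a longer chain carrying the carboxylic acid, would move the number beyond the scatter at this place. No measurement at hand offers an explanation for these readings.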